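The source may report more compounds than this note shows. Statements on the series, on what has been measured and on what is new or still open speak of the compounds shown alone.

Measured compounds in the tail flick study:
compound 1 `N=C(N)NCCC[C@H](NC(=O)CN(c1nc(Cl)nc2[nH]cnc12)C1CC1)C(=O)OCc1ccccc1`: 6.12%
compound 2 `O=C(OCc1ccccc1)[C@@H]1CCCN1C(=O)CN(c1nc(Cl)nc2[nH]cnc12)C1CC1`: 31.1%
compound 3 `C[C@H](NC(=O)CN(c1nc(Cl)nc2[nH]cnc12)C1CC1)C(=O)O`: 14.7%

All three share the same core and were tested in a functional assay on the whole organism (Tail, strain ICR) with Mus musculus as the target, in the tail flick test, with a stated time of 150 min, at a dose of 25 umol/kg by the oral route; on this read-out lower numbers stand for a weaker effect and higher numbers for a stronger effect at the one dose given. Compound 1 stands lowest of the three numbers. Its nearest neighbour is compound 3, whose number lies within the scatter of that of compound 1, so no order between those two can be claimed. Compound 2 lies beyond the scatter above compound 1.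

Compound 4 `O=C(CN(c1nc(Cl)nc2[nH]cnc12)C1CC1)N[C@@H](CCC(=O)OCc1ccccc1)C(=O)OCc1ccccc1` is still to be measured in this assay. It differs from compound 1 in one place: a group of 10 heavy atoms (8 carbon, 2 oxygen; one six-membered aromatic ring of carbon only) in place of a group of 5 heavy atoms (2 carbon, 3 nitrogen; no ring), on a saturated chain carbon, three bonds along the chain from an amide-type nitrogen and a carbonyl carbon. Within the data shown here, no pair of measured compounds differs in a single place, so no measured step tells how such a change plays out here, and the expectation rests on the spread of the three numbers alone. Since compound 2 reaches 31.1% with the same core, a step from compound 1 upward, of a size expected around the edge of the scatter, is estimated as a number 11.9 percentage points higher from compound 1 to compound 4 (beyond the scatter). Compound 4 is expected to give about 18%, most likely between 5% and 38%.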

Compound 4, a percentage reported as activity, at one dose (the size of the read-out at that dose, not a potency): 44.5%
Compound 4: middle estimate off by 26.5 percentage points, on the low side; measured number outside the range, above it.
By their numbers in this assay, from the lowest: compounds 1 and 3 (each within the scatter of the next); then compound 2; then compound 4.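

In this assay, placing a benzyloxycarbonyl group on the saturated chain carbon, three bonds along the chain from an amide-type nitrogen and a carbonyl carbon, in place of the group of 5 heavy atoms gives a number 38.4 percentage points higher from compound 1 to compound 4 (beyond the scatter). Among these compounds, this is the first single-place change, and it shows that the read-out at this dose responds strongly to what sits at this position. No measurement given here explains the size of this step.

The compounds shown leave open whether a carboxylic acid or a methyl ester at this position would behave like the benzyloxycarbonyl group, and so whether the six-membered aromatic ring matters for the step. From the compounds shown here alone, how an amine or a longer chain would read here also remains open.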